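Trimming the Phenoxy Group of Compound 3 to Chloro

The source may hold more compounds than are shown below. What is called first, only, known or untested is meant among the compounds shown, and "the series" means these compounds.

Of the compounds shown here, three on a shared core have been measured in a functional assay on MCF7 cells (Homo sapiens) for antiproliferative activity, read by sulforhodamine B assay, with a stated time of 48 h; on this read-out lower numbers stand for stronger inhibition and higher numbers for weaker inhibition. Among the measured compounds shown here, compound 1 `CCc1ccc(NS(=O)(=O)c2ccc(N3CCNC3=O)cc2)cc1` gives 810 nM, and compound 2 `O=C1NCCN1c1ccc(S(=O)(=O)Nc2ccc(F)c(F)c2)cc1` gives 620 nM; the only single-point step among them, a 1.3-fold lower number from compound 1 to compound 2 (0.12 log units; within the scatter), stays within the scatter. Compound 3 `O=C1NCCN1c1ccc(S(=O)(=O)Nc2cccc(Oc3ccccc3)c2)cc1` gives 220 nM, the lowest of the three numbers, with compound 2 standing beyond the scatter above it and compound 1 further still.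

Compound 4 `O=C1NCCN1c1ccc(S(=O)(=O)Nc2cccc(Cl)c2)cc1` is the next compound to be measured in this assay. It differs from compound 3 in one place: chloro in place of phenoxy on an aromatic carbon The change sits on the same ring that carries the varying group in compounds 1 and 2, meta to a large group. For the measured compounds named here, no measured step swaps a phenoxy for a chloro, so the only guidance is indirect: the two compounds without a phenoxy group, compound 1 and compound 2, sit well above compound 3 in this assay, and their own step from compound 1 to compound 2 was within the scatter. Compound 4 is therefore expected to move back toward those higher numbers, by about a 2.7-fold higher number from compound 3 to compound 4 (0.44 log units; beyond the scatter). Compound 4 is estimated at 600 nM, within a range from 250 nM to 1500 nM.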

Compound 4, half-maximal inhibitory concentration: 79 nM
Compound 4: middle estimate off by 7.6-fold (0.88 log units), on the high side; measured number outside the range, below it.
By their numbers in this assay, from the lowest: compound 4; then compound 3; then compounds 2 and 1 (each within the scatter of the next).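

In this assay, trimming this position did not cost activity: chloro in place of phenoxy on an aromatic carbon gives a 2.8-fold lower number from compound 3 to compound 4 (0.44 log units; beyond the scatter) and so takes the number down rather than up. The six-membered aromatic ring and the oxygen that leave with the phenoxy group are therefore not required for a low number on this core, and a single chlorine atom in their place does better. Among the groups on the sulfonamide nitrogen, 3-chlorophenyl in place of 3,4-difluorophenyl gives a 7.8-fold lower number from compound 2 to compound 4 (0.89 log units; beyond the scatter) and in place of 4-ethylphenyl gives a 10-fold lower number from compound 1 to compound 4 (1.01 log units; beyond the scatter) while the earlier step between those two groups had stayed within the scatter, so this group can move the number far more than compounds 1 and 2 suggested. Nothing measured here bears on why the number falls with this change.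

Going by these compounds, whether a methoxy or a trifluoromethyl group in the same place would match compound 4 remains open. So does whether chloro would hold its number on another carbon of that ring, and whether a second chlorine would lower it further.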